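Aminobutyl in place of sec-butyl on the shared core

The source may report more compounds than this note shows. Statements on the series, on what has been measured and on what is new or still open speak of the compounds shown alone.

Among the measured compounds shown here, compound 1 `CC[C@H](C)[C@H](NC(=O)CN(c1nc(Cl)nc2[nH]cnc12)C1CC1)C(=O)O` gives 6.71% in a functional assay on the whole organism (Tail, strain ICR) with Mus musculus as the target, in the tail flick test, with a stated time of 150 min, at a dose of 25 umol/kg by the oral route (on this read-out lower numbers stand for a weaker effect and higher numbers for a stronger effect at the one dose given), the second highest of the three numbers measured so far. Compound 2 `CC[C@H](C)[C@H](NC(=O)CN(c1nc(Cl)nc2[nH]cnc12)C1CC1)C(=O)OCc1ccccc1` gives 6.9% and compound 3 `O=C(CN(c1ncnc2c1ncn2C1CCCCO1)C1CC1)N[C@@H](CC(=O)OCc1ccccc1)C(=O)OCc1ccccc1` gives 0.06%; both stand within the scatter of compound 1, so the three numbers cannot be ordered. For the measured compounds named here, the only single-site step measured, a number 0.2 percentage points higher from compound 1 to compound 2 (within the scatter), lies within the scatter and does not touch the position changed here. Compound 4 `NCCCC[C@H](NC(=O)CN(c1nc(Cl)nc2[nH]cnc12)C1CC1)C(=O)O` differs from compound 1 by 4-aminobutyl in place of sec-butyl on a saturated chain carbon bound to an amide-type nitrogen and a carbonyl carbon. Going by the values given here, no measured step bears on this change, so nothing points in either direction, and with all numbers close together no step beyond the scatter is expected. For compound 4 the expected value is 7%, with a range from 0% to 18%. The expected step is a number 0.3 percentage points higher from compound 1 to compound 4 (within the scatter).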

Compound 4, a percentage reported as activity, at one dose (the size of the read-out at that dose, not a potency): 11.6%
Compound 4: middle estimate off by 4.6 percentage points, on the low side, within the range that was stated.
By their numbers in this assay, from the lowest: compounds 3, 1, 2 and 4 (each within the scatter of the next, the first and the last beyond it).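

In this assay, among the compounds shown here, the first change at this carbon reads as a number 4.9 percentage points higher from compound 1 to compound 4 (within the scatter) and so gives no step beyond the scatter. With the free carboxylic acid kept in place, 4-aminobutyl and sec-butyl therefore cannot be told apart on this read-out at the one dose given. No evidence on the cause bears on this result.

Still open, on these data alone, is whether a guanidine or a shorter aminopropyl chain on this carbon would give a step beyond the scatter. Also open, as far as these compounds go, is whether the benzyl ester of compound 4 would read any differently.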